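Hydroxy to hydrogen on the fused benzene ring

The source may hold more compounds than are shown below. What is called first, only, known or untested is meant among the compounds shown, and "the series" means these compounds.

Working notes on the selenium-bearing series. Compound 3 `COc1ccc2[nH]c(-c3ccc(C)[se]3)cc(=O)c2c1O` gives 900 nM in a functional assay on NCI-H460 cells (Homo sapiens) for cytotoxicity, read by MTT assay, with a stated time of 48 h (on this read-out lower numbers stand for stronger inhibition and higher numbers for weaker inhibition), the lowest of the two numbers in hand; the nearest is compound 1 `COc1ccc2[nH]c(-c3ccc[se]3)cc(=O)c2c1`, which gives 2400 nM. Compound 2 `COc1ccc2[nH]c(-c3ccc(C)[se]3)cc(=O)c2c1OC` returns only a limit of the assay, > 50000 nM. For the measured compounds named here, the one measured step at the site in question is an at least 55-fold lower number from compound 2 to compound 3 (1.74 log units; beyond the scatter), a step whose size is bounded below by the limit of > 50000 nM in this assay, at which 1 of the 3 values shown sits. Compound 4 `COc1ccc2[nH]c(-c3ccc(C)[se]3)cc(=O)c2c1` differs from compound 3 by hydrogen in place of hydroxy on an aromatic carbon. Going by the values given here, no measured step covers hydroxy to hydrogen directly; compound 1, which also carries hydrogen at that carbon and gives 2400 nM, sits a modest amount above compound 3 and is the only guide. A moderate rise in the number is therefore expected, smaller than the step from methoxy to hydroxy. Compound 4 is estimated at 2500 nM, within 800 nM to 8000 nM, an expected step of a 2.8-fold higher number from compound 3 to compound 4 (0.44 log units; beyond the scatter).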

Compound 4, half-maximal inhibitory concentration: 2000 nM
Beside the measured number, compound 4's estimate is 1.3-fold (0.10 log units) above it, and the stated range covers the measured number.
By their numbers in this assay, from the lowest: compound 3; then compounds 4 and 1 (each within the scatter of the next). At a limit, above all of these: compound 2.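

In this assay this aromatic carbon, ortho to a methoxy group, now has three substituents to compare, and hydrogen loses only a modest amount against hydroxy (a 2.2-fold higher number from compound 3 to compound 4 (0.35 log units; beyond the scatter)), whereas methoxy stands far from hydrogen (an at least 25-fold lower number from compound 2 to compound 4 (1.39 log units; beyond the scatter)), so the large loss goes with methoxy and not with the mere absence of hydroxy. Methyl in place of hydrogen on the other aromatic carbon makes no change beyond the scatter (a 1.2-fold lower number from compound 1 to compound 4 (0.08 log units; within the scatter)), which leaves hydroxy as the one change here that moves the number modestly. Compound 2 stands at a limit, so these steps are bounds: the limit of > 50000 nM in this assay, at which 1 of the 4 values shown sits.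

From the compounds shown here alone, whether an amine or a fluorine at this carbon would stay near the hydroxy number remains open. So does whether an ethoxy group would follow methoxy.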